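Cyano in place of chloro on a sulfonyl aryl group

The source may report more compounds than this note shows. Statements on the series, on what has been measured and on what is new or still open speak of the compounds shown alone.

In a functional assay on QGY-7703 cells (Homo sapiens) for cytotoxicity, read by MTT assay, with a stated time of 24 h (on this read-out lower numbers stand for stronger inhibition and higher numbers for weaker inhibition), compound 1 `O=C1/C(=C/c2ccncc2)CNC/C1=C\c1ccccc1C(F)(F)F` gives 4900 nM, compound 2 `O=C1/C(=C/c2ccncc2)CN(S(=O)(=O)c2ccccc2)C/C1=C\c1ccccc1C(F)(F)F` gives 6210 nM, and compound 3 `O=C1/C(=C/c2ccncc2)CN(S(=O)(=O)c2ccc(Cl)cc2)C/C1=C\c1ccccc1C(F)(F)F` gives 12700 nM, the highest of these numbers. Compound 4 `N#Cc1ccc(S(=O)(=O)N2C/C(=C\c3ccncc3)C(=O)/C(=C/c3ccccc3C(F)(F)F)C2)cc1` differs from compound 3 in one place, with cyano in place of chloro on an aromatic carbon. Adding the unsubstituted sulfonyl group gave a 1.3-fold higher number from compound 1 to compound 2 (0.10 log units; within the scatter). Chloro in place of hydrogen on that aromatic carbon gave a 2.0-fold higher number from compound 2 to compound 3 (0.31 log units; beyond the scatter), a modest step. Within the data shown here, no measured compound carries cyano, so these steps offer only a rough guide. A small change is therefore expected, and the estimated step is a 1.3-fold lower number from compound 3 to compound 4 (0.10 log units; within the scatter). For compound 4 the expected value is 10000 nM, with an estimated range of 4500 nM to 22000 nM.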

Compound 4, half-maximal inhibitory concentration: 6290 nM
Estimate against measurement, compound 4: 1.6-fold (0.20 log units) above; the range from low to high includes it.
By their numbers in this assay, from the lowest: compounds 1, 2 and 4 (each within the scatter of the next); then compound 3.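

In this assay the exchange of chloro for cyano gives a 2.0-fold lower number from compound 3 to compound 4 (0.31 log units; beyond the scatter) and so shows that this aromatic carbon is sensitive to the group it carries. Cyano in place of hydrogen gives a 1.0-fold higher number from compound 2 to compound 4 (0.01 log units; within the scatter) and so, unlike chloro, leaves the number within the scatter of the unsubstituted phenylsulfonyl compound. The full (4-cyanophenyl)sulfonyl group in place of the ring hydrogen gives a 1.3-fold higher number from compound 1 to compound 4 (0.11 log units; within the scatter) and is likewise within the scatter. Nothing available here gives a reason for the difference between chloro and cyano. Going by these compounds, whether an amine or a carboxylic acid on this aromatic carbon would track with chloro or with cyano remains open.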